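This account rests on a few compounds, and the source may have more. Where it says the series, first, only, none or still open, it means among the compounds named here.

Series notes, piperidine amides. Two compounds are measured in an assay on THP-1 cells for displacement of a labelled ligand from C-C chemokine receptor type 1 (Homo sapiens); on this read-out lower numbers stand for stronger inhibition and higher numbers for weaker inhibition. Compound 1 `CC(C)C(NS(=O)(=O)Cc1ccccc1)C(=O)N1CCC(c2ccc(Cl)cc2)CC1` carries a benzylsulfonamide on the valine nitrogen; in this assay compound 1 gives 303 nM. Compound 2 `CC(C)[C@@H](NC(=O)c1nc2ccccc2s1)C(=O)N1CCC(c2ccc(Cl)cc2)CC1` carries instead an aromatic carboxamide; in this assay compound 2 gives 18 nM. Compound 2 therefore stands at the lowest number of the two, and the gap to compound 1 lies beyond the usual scatter of this assay, so the two pieces of data can be read as distinct. With only two points, nothing can yet be said about any trend within the series.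

Compound 3 `CC(C)CC(=O)N[C@@H](C(=O)N1CCC(c2ccc(Cl)cc2)CC1)C(C)C` is the next step from compound 2: isobutyl in place of 1,3-benzothiazol-2-yl on a carbonyl carbon. The aromatic bicycle is replaced by a short branched chain, with the rest of the core kept. Within the data shown here, no comparable step has been measured here, so the direction has to be judged from the two points given: the weakest compound so far, compound 1, is the one without a carboxamide-linked aromatic, which argues that a loss beyond the scatter is more likely than a gain. The step from compound 2 to compound 3 is expected to be an 8.3-fold higher number from compound 2 to compound 3 (0.92 log units; beyond the scatter), towards a higher number. For compound 3 in this assay the estimate is 150 nM, with a range from 40 nM to 600 nM.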

Compound 3, half-maximal inhibitory concentration: 32 nM
The estimate for compound 3 lay 4.7-fold (0.67 log units) above the measured number, and the stated range ends above it.
By their numbers in this assay, from the lowest: compounds 2 and 3 (each within the scatter of the next); then compound 1.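

In this assay, isobutyl in place of 1,3-benzothiazol-2-yl on a carbonyl carbon gives a 1.8-fold higher number from compound 2 to compound 3 (0.25 log units; within the scatter), so this read-out does not separate the two groups at this position. With the rest of the shared core kept, the aromatic rings and hydrogen-bond acceptors of the 1,3-benzothiazol-2-yl are therefore not required here for a number in this range, since a branched chain with no ring and no acceptor gives a result within the scatter. Nothing available explains why the two groups cannot be told apart, so this remains an observation from one matched pair.

Open, as far as these compounds go, is how much variation this carbonyl carbon accepts: a methyl, a longer chain such as n-hexyl, a chain ending in an amine or a carboxylic acid, or a plain phenyl could each stay in this range or leave it. Also open, from the compounds shown here alone, is whether the same tolerance holds when the group on the carbonyl carbon is changed together with another part of the shared core, as a single pair cannot show whether the two places act independently.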